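The source may hold more compounds than are shown below. What is called first, only, known or untested is meant among the compounds shown, and "the series" means these compounds.

In a functional assay on KG-1 cells (Homo sapiens) for cytotoxicity, read by luminescence and CellTiter-Glo, with a stated time of 3 days (a lower number here means a stronger inhibitor, a higher number a weaker inhibitor), compound 1 `N#Cc1ccc(NC(=O)c2ccc(C(F)(F)F)cc2O)cc1` gives 1440 nM and compound 2 `O=C(Nc1ccc(C(F)(F)F)cc1)c1ccc(F)cc1O` gives 740 nM as its value, and these two numbers lie within the usual scatter of each other. Going to compound 3 `N#Cc1ccc(NC(=O)c2ccc(F)cc2O)cc1` from compound 2 puts cyano in place of trifluoromethyl on an aromatic carbon, and cyano in place of trifluoromethyl on an aromatic carbon sums up that change. Among the compounds with values here, no measured pair shows this swap alone. Compound 1 also carries cyano and gives 1440 nM in this assay so a small rise is expected, hardly beyond the scatter. The estimated change is a 2.0-fold higher number from compound 2 to compound 3 (0.31 log units; beyond the scatter) in size. For compound 3 the expected value is 1500 nM within an estimated range of 600 nM to 4000 nM in this measurement.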

Compound 3, half-maximal inhibitory concentration: 3150 nM
Compound 3: middle estimate off by 2.1-fold (0.32 log units), on the low side; the measured number falls inside the stated range.
By their numbers in this assay, from the lowest: compounds 2 and 1 (each within the scatter of the next); then compound 3.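

Putting cyano in place of trifluoromethyl on the aromatic carbon para to a large group gives a 4.3-fold higher number from compound 2 to compound 3 (0.63 log units; beyond the scatter), a first clear loss of strength at this position. Exchanging trifluoromethyl for fluoro gives a 2.2-fold higher number from compound 1 to compound 3 (0.34 log units; beyond the scatter), so both single changes that remove trifluoromethyl weaken the compound, and compound 3, which ends both steps, carries none. Nothing available explains this loss. As far as these compounds go, whether a chloro or methoxy group at this position would keep the strength of trifluoromethyl remains open.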